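Naphthalenyl in Place of Nitrophenyl on the Aromatic Carbon

The compounds below may be only part of what the source reports. "The series", "measured", "known", "first", "only" and "open" are said of these compounds alone.

Of the compounds shown here, two have been measured so far. Compound 1 `C=C(CC)C(=O)c1ccc(OCc2nc(-c3ccc4ccccc4c3)cs2)cc1Cl` gives 9.5% in an assay on HL-60 cells for inhibition of glutathione S-transferase P (Homo sapiens), read by spectrophotometry, tested at 5 uM; a higher number here means more inhibition at the concentration tested (going by the name of the read-out), a lower number less inhibition. Compound 2 `C=C(CC)C(=O)c1ccc(OCc2nc(-c3ccc([N+](=O)[O-])cc3)cs2)c(Cl)c1Cl` gives 8.1% in this assay, which puts it at the bottom of the two numbers shown, though compound 1 sits within the usual scatter of it, so the two values cannot be told apart. Compound 3 `C=C(CC)C(=O)c1ccc(OCc2nc(-c3ccc4ccccc4c3)cs2)c(Cl)c1Cl` has not yet been measured. It differs from compound 2 in one place: naphthalen-2-yl in place of 4-nitrophenyl on an aromatic carbon. Compound 1 already carries the same naphthalen-2-yl group, and its value does not stand apart from that of compound 2. On that basis the step of a number 0.9 percentage points higher from compound 2 to compound 3 (within the scatter) is expected to stay within the scatter, with no clear direction. Compound 3 is accordingly estimated at 9%, in a range from 0% to 20%.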

Compound 3, a percentage reported as inhibition, at one concentration (the size of the read-out at that concentration, not a potency): 4.3%
Compound 3: middle estimate off by 4.7 percentage points, on the high side; the measured number falls inside the stated range.
By their numbers in this assay, from the lowest: compounds 3, 2 and 1 (each within the scatter of the next).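

In this assay, naphthalen-2-yl in place of 4-nitrophenyl on the aromatic carbon of the five-membered ring gives a number 3.8 percentage points lower from compound 2 to compound 3 (within the scatter) on an otherwise identical structure, so this exchange has now been read directly and shows no difference that stands clear of the scatter. Chloro in place of hydrogen on an aromatic carbon, a second place not read before, gives a number 5.2 percentage points lower from compound 1 to compound 3 (within the scatter) and likewise cannot be told from the scatter. No measurement at hand bears on either step.

The three numbers do not separate, so the compounds shown leave open whether any group at the position on the five-membered ring can change inhibition at the concentration tested. A small methyl group there, or an aromatic ring bearing an amine or a carboxylic acid, remains an open case.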